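Hydroxy for Methoxy on a Weak Melanoma Cell Inhibitor

A few compounds are considered here, and "the series" means these few. Any claim that something is new, unique, unknown or untested is made for them only; others in the source may bear on it.

The compounds here were tested in a functional assay on B16-F10 cells (Mus musculus) for inhibition, read by colorimetric assay and MTT assay, with a stated time of 72 h; on this read-out higher numbers stand for weaker inhibition and lower numbers for stronger inhibition. Going by the values given here, compound 1, with the structure `COc1ccc(-c2nnc(Nc3csc(-c4ccccc4)c3)s2)cc1`, is the only one with a number: in this assay compound 1 gives 6000 nM, which marks it as a weak inhibitor in this setting. Compound 2, `COc1ccc(-c2nnc(Nc3csc(-c4ccc(C)cc4)c3)s2)cc1`, was also examined, but in this assay compound 2 is recorded as "not determined" (no result reported), so compound 2 stands nowhere on the numbers and offers no anchor of its own.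

Compound 3, `Cc1ccc(-c2cc(Nc3nnc(-c4ccc(O)cc4)s3)cs2)cc1`, differs from compound 2 by hydrogen in place of methyl on an oxygen on an aromatic ring. Among the compounds with values here, no measured pair in this set shows what such a change does, so the expectation rests on the lone number from compound 1 and on the fact that the change removes only a single carbon. For this assay a step of modest size is expected, in either direction or none beyond the scatter, with weak inhibition most likely retained. Compound 3 is therefore expected to give about 5000 nM in this assay, with a plausible range from 1500 nM to 20000 nM.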

Compound 3, half-maximal inhibitory concentration: 6000 nM
Compound 3: middle estimate off by 1.2-fold (0.08 log units), on the low side; low and high end bracket the measured number.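

Compound 2 has no number to set against that of compound 3, so no step can be read between them. What the change from methoxy to hydroxy does to inhibition in this assay stays open in the compounds shown. No measurement offered here bears on the value of compound 3.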